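Adding a Propyl Chain to an Inactive Parent

A few compounds are considered here, and "the series" means these few. Any claim that something is new, unique, unknown or untested is made for them only; others in the source may bear on it.

Compound 1 `CCCC(CCO)n1cnc2c(Cl)nc(F)nc21` and compound 2 `CCCC(CCO)n1cnc2c(Cl)ncnc21` share one core and differ at a single aromatic carbon. In a functional assay on SW480 cells (Homo sapiens) for antiproliferative activity, read by MTT assay, with a stated time of 48 h (a higher number here means a weaker inhibitor, a lower number a stronger inhibitor), compound 1 gives 17200 nM. Compound 2 gives > 50000 nM, which is a limit of the assay and not a number. Among the measured compounds shown here, the only measured step, an at least 2.9-fold higher number from compound 1 to compound 2 (0.46 log units; beyond the scatter), concerns hydrogen in place of fluoro and says nothing about a longer chain. Compound 3 `CCCCCCC(CCO)n1cnc2c(Cl)ncnc21` differs from compound 2 by propyl in place of hydrogen on a saturated chain carbon, four bonds along the chain from an aromatic nitrogen. For the measured compounds named here, no measured step bears on this change, so there is no ground to expect a shift beyond the scatter in this assay in either direction. Because compound 2 sits at the limit of > 50000 nM in this assay, at which 1 of the 2 values shown sits, the most likely outcome is that compound 3 also returns only a limit. Compound 3 is therefore estimated near 60000 nM, between 15000 nM and 200000 nM. The expected step that the limit leaves unreadable from compound 2 to compound 3 is essentially flat.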

Compound 3, half-maximal inhibitory concentration: 16700 nM
Beside the measured number, compound 3's estimate is 3.6-fold (0.56 log units) above it, and the stated range covers the measured number.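

Propyl in place of hydrogen on a saturated chain carbon, four bonds along the chain from an aromatic nitrogen, moves the result in this assay, with an at least 2.9-fold lower number from compound 2 to compound 3 (0.47 log units; beyond the scatter). Among the compounds shown here, the earlier compounds showed a response only to a change on an aromatic carbon, so this is the first sign that the chain carbon also matters. The full size of the step cannot be read, because compound 2 is held only by a limit of the assay and not by a number: the limit of > 50000 nM in this assay, at which 1 of the 3 values shown sits.

The compounds shown do not tell whether a longer chain or an amine on this chain carbon would lower the number further. They also leave open what propyl does when fluoro stands on the aromatic carbon.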